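Working notes on the series: compound 3 to compound 4

This account rests on a few compounds, and the source may have more. Where it says the series, first, only, none or still open, it means among the compounds named here.

The series shares a core seen in compound 1 `CC(C(=O)N1CCN(c2ccccc2F)CC1)N1C(=O)CCC1=O`, compound 2 `CCC(C(=O)N1CCN(c2cccc(C)c2)CC1)N1C(=O)CCC1=O` and compound 3 `CC(C(=O)N1CCN(c2cccc(C(F)(F)F)c2)CC1)N1C(=O)CCC1=O`. In a functional assay on the whole organism (strain Swiss) with Mus musculus as the target, in the maximal electroshock model, with a stated time of 2 h, at a dose of 100 mg/kg by the intraperitoneal route (on this read-out higher numbers stand for a stronger effect at the one dose given and lower numbers for a weaker effect), compound 1 gives 0%. In this assay compound 2 gives 0%. In this assay, among the measured compounds shown here, compound 3 gives 0%, level with compound 1 and compound 2 within the scatter, so no compound stands apart here. Compound 4 `Cc1cccc(N2CCN(C(=O)C(C)N3C(=O)CCC3=O)CC2)c1` is not yet measured. It differs from compound 3 by methyl in place of trifluoromethyl on an aromatic carbon. Compound 2 already carries a methyl on its aromatic ring and shows no effect, so for compound 4 no step beyond the scatter is expected, because compound 2 gives 0%. The expected step of no change at the digits printed from compound 3 to compound 4 (within the scatter) is none. For compound 4 the estimate in this assay is 0%, in the range 0% to 10%.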

Compound 4, a percentage reported as activity, at one dose (the size of the read-out at that dose, not a potency): 0%
Estimate against measurement, compound 4: no gap at the digits printed; low and high end bracket the measured number.
By their numbers in this assay, from the lowest: compounds 1, 2, 3 and 4 (each within the scatter of the next).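

In this assay there is no change at the digits printed from compound 3 to compound 4 (within the scatter) for methyl in place of trifluoromethyl on an aromatic carbon, so neither group separates from the other at this position at the one dose given. There is also no change at the digits printed from compound 2 to compound 4 (within the scatter) for hydrogen in place of methyl on a saturated chain carbon, and no change at the digits printed from compound 1 to compound 4 (within the scatter) for 3-methylphenyl in place of 2-fluorophenyl on an amine nitrogen in a ring. Nothing available bears on the reason for this flat result.

With all four compounds level, these changes give no direction for the series. On these data alone, it remains open whether an amine or a carboxylic acid on the aromatic ring, or a longer chain on the saturated carbon, would give any effect at this dose.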